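This account rests on a few compounds, and the source may have more. Where it says the series, first, only, none or still open, it means among the compounds named here.

Measured compounds in the series:

compound 1, `CCCCCCCCNC(=O)[C@@H](NC(=O)c1nccc2ccccc12)[C@@H](C)O`: in a functional assay on SW-620 cells (Homo sapiens) for cytotoxicity, read by MTT assay, with a stated time of 48 h (a higher number here means a weaker inhibitor, a lower number a stronger inhibitor), compound 1 gives 67800 nM
compound 2, `CCCCCCCCCCCCCCNC(=O)[C@@H](NC(=O)c1cc2ccccc2o1)[C@@H](C)O`: in this assay compound 2 gives 26700 nM

Compound 2 holds the lower of the two numbers; compound 1 sits beyond the scatter above it. Among the compounds with values here, the two measured compounds differ in two places at once, the chain on the amide nitrogen and the aromatic group on the carbonyl, so no step that isolates one change is available, and the gap between compound 1 and compound 2 cannot be assigned to either part.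

Compound 3, `CCCCCCCCCCCCCCNC(=O)[C@@H](NC(=O)c1nccc2ccccc12)[C@@H](C)O`, keeps the chain of compound 2 and carries the aromatic group of compound 1: isoquinolin-1-yl in place of 1-benzofuran-2-yl on a carbonyl carbon. Compound 3 thus combines the tetradecyl chain with the isoquinolin-1-yl group. Within the data shown here, with no single-point step on record, the expected step in this assay is a small one, of uncertain direction, most likely within the scatter or only slightly beyond it toward a weaker inhibitor, as the expected 1.4-fold higher number from compound 2 to compound 3 (0.15 log units; within the scatter) indicates. The estimate for compound 3 is 38000 nM, with a range from 13000 nM to 110000 nM.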

Compound 3, half-maximal inhibitory concentration: 30400 nM
For compound 3 the middle estimate is 1.3-fold (0.10 log units) above the measured one; measured number inside the range.
By their numbers in this assay, from the lowest: compounds 2 and 3 (each within the scatter of the next); then compound 1.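

In this assay, isoquinolin-1-yl in place of 1-benzofuran-2-yl on a carbonyl carbon gives a 1.1-fold higher number from compound 2 to compound 3 (0.06 log units; within the scatter), so with the tetradecyl chain held fixed, this exchange of aromatic groups does not separate the two compounds. The chain now has a step of its own: with isoquinolin-1-yl held fixed, hexyl in place of hydrogen on a saturated chain carbon, eight bonds along the chain from an amide-type nitrogen, gives a 2.2-fold lower number from compound 1 to compound 3 (0.35 log units; beyond the scatter), a modest step that lies beyond the scatter, unlike the step on the aromatic group. No supporting data bear on the reason for either step.

The compounds shown leave open whether the two aromatic groups also stay level on the shorter chain of compound 1, since the exchange is read on the tetradecyl chain alone. They also leave open whether the trend on the chain goes on to a longer chain such as octadecyl, and what a carboxylic acid or an amine at the end of the chain would do to the number.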